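A Second Fluorine on the Outer Phenyl Ring

This account rests on a few compounds, and the source may have more. Where it says the series, first, only, none or still open, it means among the compounds named here.

Compound 1 `COc1cc2c(Oc3ccc(NC(=O)c4cc(-c5ccccc5)ccn4)cc3F)ccnc2cc1OCCCN1CCCC1` and compound 2 `COc1cc2c(Oc3ccc(NC(=O)c4cc(-c5ccccc5F)ccn4)cc3F)ccnc2cc1OCCCN1CCCC1` share one core; compound 3 `COc1cc2c(Oc3ccc(NC(=O)c4nccc(-c5ccc(F)cc5)n4)cc3F)ccnc2cc1OCCCN1CCN(C)CC1` and compound 4 `COc1cc2c(Oc3ccc(NC(=O)c4nccc(-c5ccc(F)cc5F)n4)cc3F)ccnc2cc1OCCCN1CCN(C)CC1` share another, and the difference between the two cores is not broken down here. In a functional assay on NCI-H460 cells (Homo sapiens) for cytotoxicity, read by MTT assay, with a stated time of 72 h (on this read-out lower numbers stand for stronger inhibition and higher numbers for weaker inhibition), compound 1 gives 130 nM and compound 2 gives 140 nM. The change between them, (fluoro in place of hydrogen on an aromatic carbon), made a 1.1-fold higher number from compound 1 to compound 2 (0.03 log units; within the scatter). In this assay compound 3 gives 63 nM, the lowest of the three numbers. Compound 4 differs from compound 3 by fluoro in place of hydrogen on an aromatic carbon; here the place is also meta to a fluoro group, so this is the same kind of change rather than the same one. The step is expected to be a 1.1-fold higher number from compound 3 to compound 4 (0.05 log units; within the scatter), which rests on the earlier step of a 1.1-fold higher number from compound 1 to compound 2 (0.03 log units; within the scatter). Compound 4 is therefore estimated at 70 nM, with a range from 35 nM to 140 nM.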

Compound 4, half-maximal inhibitory concentration: 450 nM
Compound 4: the middle estimate sits 6.4-fold (0.81 log units) below what was measured; the whole stated range lies below it.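

In this assay, adding the second fluoro group, which turns 4-fluorophenyl into 2,4-difluorophenyl, gave a 7.1-fold higher number from compound 3 to compound 4 (0.85 log units; beyond the scatter). The same kind of change therefore did not carry over unchanged from one core to the other, and a small step on one core was no safe guide to the step on the other: the same change on two cores in this assay, a 1.1-fold higher number (0.03 log units; within the scatter) from compound 1 to compound 2 and a 7.1-fold higher number (0.85 log units; beyond the scatter) from compound 3 to compound 4, 6.6-fold (0.82 log units) apart, beyond the scatter of two such steps

This does not show which difference is responsible, since the cores differ and the new fluoro group in compound 4 is also meta to a fluoro group, and two pairs cannot separate these. From the compounds shown here alone, it remains open whether the higher number belongs to fluoro itself or would also follow from a chloro or methyl group at that place on the core of compound 3.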